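Chain unsaturation versus chain length in the acyl series

The source may report more compounds than this note shows. Statements on the series, on what has been measured and on what is new or still open speak of the compounds shown alone.

The compounds share one core and differ only in the acyl chain attached to the amide. Compound 1 `CCCCCCCCCCCCCCCC(=O)NCCC(=O)Nc1cccc(S(=O)(=O)Nc2cccc(C)c2C)c1` is tested in an in vitro assay on Sf9 cells for inhibition of CAAX prenyl protease 2 (Homo sapiens), tested at 10 uM (on this read-out lower numbers stand for less inhibition and higher numbers for more inhibition at the one concentration tested (going by the name of the read-out)), and gives 18%. Compound 2 `CCCCCCCCCCCCCC(=O)NCCC(=O)Nc1cccc(S(=O)(=O)Nc2cccc(C)c2C)c1` reaches only a limit of the assay in this assay, < 5%. Compound 3 `CCCCCCCCCCCCCCCCCC(=O)NCCC(=O)Nc1cccc(S(=O)(=O)Nc2cccc(C)c2C)c1` likewise reaches only a limit in this assay, < 5%. The two steps away from compound 1 read as a number at least 13 percentage points lower from compound 1 to compound 2 (beyond the scatter) and a number at least 13 percentage points lower from compound 1 to compound 3 (beyond the scatter); the step between the two shorter and longer chains, a step that the two limits leave unreadable from compound 2 to compound 3, cannot be read because of the limit of < 5% in this assay, at which 2 of the 3 values shown sit.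

Compound 4 `CCCCCCCC/C=C\CCCCCCCC(=O)NCCC(=O)Nc1cccc(S(=O)(=O)Nc2cccc(C)c2C)c1` is not yet measured. It differs from compound 3 by dec-1-en-1-yl in place of decyl on a saturated chain carbon, seven bonds along the chain from a carbonyl carbon; the chain keeps its length, and only its saturation changes. For the measured compounds named here, none of the measured steps covers such a change: all three alter chain length only, and compound 3, the chain-length match of compound 4, sits at the limit. With no measured evidence on unsaturation, compound 4 is expected to stay close to compound 3, with a number at least 3 percentage points higher from compound 3 to compound 4 (that floor lies within the scatter) small or not readable. The estimate for compound 4 in this assay is 8%, within 3% to 20%.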

Compound 4, a percentage reported as inhibition, at one concentration (the size of the read-out at that concentration, not a potency): < 5%
Compound 4 ended at the assay's limit; the forecaster's own chance of this, stated with the estimate: 50%; middle value at least 3 percentage points from the limit.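

In this assay compound 4 sits at a limit of the assay, < 5%, so dec-1-en-1-yl in place of decyl, seven bonds along the chain from a carbonyl carbon, gives no readable gain at this position. Against the shorter saturated chain of compound 1, the reading is a number at least 13 percentage points lower from compound 1 to compound 4 (beyond the scatter), so the unsaturated chain joins compound 2 and compound 3 in falling short of compound 1, the only compound shown with a value clear of the limit. The steps to compound 4 from compound 2 and from compound 3 cannot be read: the limit of < 5% in this assay, at which 3 of the 4 values shown sit.

Going by these compounds, whether the double bond has any effect on inhibition remains open, as the read-out gives no number for either chain of this length, and the same holds for a trans double bond at this position. Also open, on these data alone, is how a double bond would read in a chain of the length of compound 1, and whether a terminal carboxylic acid or amine on the chain would raise the inhibition.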